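Piperazine for ethyl(propyl)amino: a cytotoxicity estimate

The compounds below may be only part of what the source reports. "The series", "measured", "known", "first", "only" and "open" are said of these compounds alone.

In an ADME assay on Huh7.5.1 cells (Homo sapiens) for cytotoxicity, read by WST assay, with a stated time of 48 h (a lower number here means that less compound is tolerated, a higher number that more compound is tolerated), compound 2 `CCCN(CC)c1ccc(Oc2ccc(-c3[nH]c4cccc(F)c4c(=O)c3C)cc2F)cc1` gives > 10000 nM as a limit and not as a number. Compound 1 `Cc1c(-c2ccc(Cc3ccc(OCC(F)(F)F)cc3)cc2)[nH]c2cccc(F)c2c1=O` gives > 5000 nM as a limit too. Among the measured compounds shown here, the change piperazin-1-yl in place of ethyl(propyl)amino on an aromatic carbon puts piperazin-1-yl in place of ethyl(propyl)amino on an aromatic carbon, giving compound 3 `Cc1c(-c2ccc(Oc3ccc(N4CCNCC4)cc3)c(F)c2)[nH]c2cccc(F)c2c1=O` with no measurement yet. The expected step of an at least 1.2-fold lower number from compound 2 to compound 3 (0.09 log units; that floor lies within the scatter) is small, slightly towards less compound tolerated and within the usual scatter. In this assay the estimated value for compound 3 is 8000 nM with an expected range from 2500 nM to 25000 nM for this measurement.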

Compound 3, half-maximal cytotoxic concentration: > 10000 nM
Compound 3: no number, only a limit (the forecaster's own chance of this, stated with the estimate: 55%); middle value at least 1.2-fold (0.09 log units) away from the limit.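

Compound 2 and compound 3 each give only a limit and not a number, so no step can be read between them: the limit of > 10000 nM in this assay, at which 2 of the 3 values shown sit.

From the compounds shown here alone, whether piperazin-1-yl in place of ethyl(propyl)amino changes the tolerated concentration in this assay stays open.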